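Halogen variation on the benzamide in an antiproliferative series

The source may report more compounds than this note shows. Statements on the series, on what has been measured and on what is new or still open speak of the compounds shown alone.

Measured compounds:
compound 1, `NC(=O)c1c(NC(=O)c2ccccc2Cl)sc2c1CCN(C(=S)Nc1ccccc1Br)C2`: 10800 nM
compound 2, `NC(=O)c1c(NC(=O)c2ccccc2Br)sc2c1CCN(C(=S)Nc1ccccc1Br)C2`: 13700 nM

Both numbers come from a functional assay on MKN-74 cells (Homo sapiens) for antiproliferative activity, with a stated time of 24 h; on this read-out higher numbers stand for weaker inhibition and lower numbers for stronger inhibition. Within the data shown here, compound 2 holds the highest of the two numbers, with compound 1 as its only neighbour; the step of a 1.3-fold higher number from compound 1 to compound 2 (0.10 log units; within the scatter) lies within the scatter, so the two compounds cannot be ordered against each other on this read-out.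

Compound 3, `NC(=O)c1c(NC(=O)c2ccccc2I)sc2c1CCN(C(=S)Nc1ccccc1Br)C2`, is not yet measured. It differs from compound 2 in one place: iodo in place of bromo on an aromatic carbon. Among the measured compounds shown here, the only measured step that bears on this change is the one from chloro to bromo, a 1.3-fold higher number from compound 1 to compound 2 (0.10 log units; within the scatter), which did not move the number beyond the scatter. On that single step, the next halogen exchange is expected to change this assay by about a 1.1-fold higher number from compound 2 to compound 3 (0.04 log units; within the scatter), that is, no step beyond the scatter in either direction, though one prior step is a thin basis.

The expected value for compound 3 in this assay is therefore 15000 nM, with a range from 6000 nM to 40000 nM.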

Compound 3, half-maximal inhibitory concentration: 22400 nM
Compound 3: middle estimate off by 1.5-fold (0.17 log units), on the low side; the measured number falls inside the stated range.
By their numbers in this assay, from the lowest: compounds 1, 2 and 3 (each within the scatter of the next, the first and the last beyond it).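

On the halogen at this aromatic carbon, ortho to a large group, replacing bromo with iodo in this assay (a 1.6-fold higher number from compound 2 to compound 3 (0.21 log units; within the scatter)) leaves the two compounds unordered, just as chloro and bromo were, so no single exchange of neighbouring halogens yet separates compounds on this read-out. Among these compounds, the wider exchange of chloro for iodo (a 2.1-fold higher number from compound 1 to compound 3 (0.32 log units; beyond the scatter)) is the first difference at this position to clear the scatter: compound 3 is modestly weaker than compound 1, although the bromo compound cannot be ordered against either, so this is one end-to-end difference and not a resolved stepwise trend. No measurement available here explains this difference.

Still open, on these data alone, is whether the step seen across these halogens extends to fluoro or to hydrogen at the same carbon, and whether a non-halogen group such as methoxy, an amine or a carboxylic acid would leave the number in the same range. Also open, as far as these compounds go, is whether the modest difference between chloro and iodo persists when the 2-bromophenyl group on the other side of the core is replaced, for example by an unsubstituted phenyl.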